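Furan-2-yl for Thiophen-3-yl: A Step Expected to Stay Silent

The source may report more compounds than this note shows. Statements on the series, on what has been measured and on what is new or still open speak of the compounds shown alone.

Compound 1 `Nc1nc(N)c2c(-c3ccsc3)cn([C@@H]3O[C@H](CO)[C@@H](O)[C@H]3O)c2n1` was tested in an ADME assay on BJ cells (Homo sapiens), read by MTT assay, with a stated time of 72 h; on this read-out higher numbers stand for weaker inhibition and lower numbers for stronger inhibition. In this assay compound 1 gives > 100000 nM, which is a limit of the assay rather than a number. Two neighbours differ from compound 1 in one place. Compound 2 `COc1nc(N)nc2c1c(-c1ccsc1)cn2[C@@H]1O[C@H](CO)[C@@H](O)[C@H]1O` carries a methoxy in place of amino on an aromatic carbon; in this assay compound 2 gives > 100000 nM, again a limit. Compound 3 `Cc1nc(N)c2c(-c3ccsc3)cn([C@@H]3O[C@H](CO)[C@@H](O)[C@H]3O)c2n1` carries a methyl in place of amino on an aromatic carbon; in this assay compound 3 gives > 100000 nM, also a limit. The two measured steps, a step that the two limits leave unreadable from compound 1 to compound 2 and a step that the two limits leave unreadable from compound 1 to compound 3, cannot be sized because the limit of > 100000 nM in this assay, at which 3 of the 3 values shown sit, holds every value shown. Compound 1 thus stands at that limit, alongside compound 2 and compound 3.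

Compound 4 `Nc1nc(N)c2c(-c3ccco3)cn([C@@H]3O[C@H](CO)[C@@H](O)[C@H]3O)c2n1` has not been measured. It differs from compound 1 as follows: furan-2-yl in place of thiophen-3-yl on an aromatic carbon. Neither measured step touches this position, and both were unreadable, so no direction can be drawn from them. The account therefore expects no step beyond the scatter, a number no higher from compound 1 to compound 4 (the limit leaves the size open), and most likely another limit. Compound 4 is estimated at 100000 nM, within 30000 nM to 300000 nM.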

Compound 4, half-maximal inhibitory concentration: > 100000 nM
Compound 4: no number, only a limit; the forecaster's own chance of this, stated with the estimate: 85%; the middle value sits exactly at the limit.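

The step from compound 1 to compound 4 cannot be read, because both compounds stand at the same limit rather than at a number: the limit of > 100000 nM in this assay, at which 4 of the 4 values shown sit.

The compounds shown leave open how far beyond this limit each one lies, and whether furan-2-yl and thiophen-3-yl differ at all in this assay.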